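A few compounds are considered here, and "the series" means these few. Any claim that something is new, unique, unknown or untested is made for them only; others in the source may bear on it.

Of the compounds shown here, two that share one core have been measured in a functional assay on MDA-MB-435 cells (Homo sapiens) for inhibition, read by sulforhodamine B assay, with a stated time of 48 h; on this read-out higher numbers stand for weaker inhibition of growth and lower numbers for stronger inhibition of growth. Compound 1 `COc1cc(C)cc(-c2c(-c3ccnc(-c4ccc(C(C)=O)cc4)c3)cnn2CC#N)c1` gives 1930 nM in this assay. Compound 2 `COc1cc(C)cc(-c2nn(CC#N)cc2-c2ccc(-c3cccc(C(C)=O)c3)nc2)c1` gives 3410 nM in this assay. Compound 1 holds the lower of these two numbers, yet compound 2 stands close to it, and the gap between them lies within the scatter of repeated measurements, so the two cannot be told apart on these numbers alone.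

Compound 3 `COc1cc(C)cc(-c2c(-c3ccnc(-c4ccc(N(C)C)cc4)c3)cnn2CC#N)c1` has not yet been measured. It differs from compound 1 in a single place: dimethylamino in place of acetyl on an aromatic carbon. Among the compounds with values here, no pair of measured compounds shows what this exchange does, so nothing about its size or its direction can be read from the numbers at hand. A step of a 1.0-fold higher number from compound 1 to compound 3 (0.02 log units; within the scatter) is expected, which is no more than the scatter itself allows. Compound 3 is therefore estimated to give about 2000 nM in this assay, with a range from 600 nM to 7000 nM that is kept wide enough to cover a modest change in either direction.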

Compound 3, concentration for 50% growth inhibition: 22.6 nM
Beside the measured number, compound 3's estimate is 88-fold (1.95 log units) above it; the measured number lies below the stated range.
By their numbers in this assay, from the lowest: compound 3; then compounds 1 and 2 (each within the scatter of the next).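

The position on the six-membered aromatic ring of carbon only, para to a large group, turns out to be highly sensitive to what it carries: in this assay, putting dimethylamino in place of acetyl gives an 85-fold lower number from compound 1 to compound 3 (1.93 log units; beyond the scatter). The earlier compounds shown here could not show this, since compounds 1 and 2 differ in more than one place and their values lie within the scatter of each other. The two groups match in heavy-atom count, hydrogen-bond donors, hydrogen-bond acceptors and net charge, so these counts do not separate them, and no measurement at hand bears on why the exchange has so large an effect.

From the compounds shown here alone, it remains open whether this stronger inhibition of growth is tied to dimethylamino itself or would also appear with a smaller amine such as methylamino, a ring amine such as pyrrolidine, or an ether such as methoxy. Going by these compounds, it is also open whether dimethylamino in place of acetyl would produce a step of similar size on the framework of compound 2.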